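The source may hold more compounds than are shown below. What is called first, only, known or untested is meant among the compounds shown, and "the series" means these compounds.

Of the compounds shown here, two sharing one core have been measured in an in vitro ADME assay on microsomes from liver (Mus musculus) for pharmacokinetics, tested at 1 uM; on this read-out lower numbers stand for slow clearance and higher numbers for fast clearance. Compound 1 `CC1(C)C[C@H](O)C[C@](C)(CNC(=O)c2ccccc2O)C1` gives 76.7 mL/min/kg in this assay. Compound 2 `CC1(C)C[C@H](O)C[C@](C)(CNc2ccccc2)C1` gives 85.6 mL/min/kg in this assay, a number that sits within the usual scatter of the value of compound 1, so the two cannot be told apart on this read-out. Compound 3 `CC1(C)C[C@H](O)C[C@](C)(CNc2cccc(S(N)(=O)=O)c2)C1` has not yet been measured. It differs from compound 2 in one place: sulfamoyl in place of hydrogen on an aromatic carbon. For the measured compounds named here, no measured pair shows what this change does in this assay, so the direction of the step has to be anticipated rather than read off. A step to a lower number, modestly beyond the scatter, is expected for a 1.9-fold lower number from compound 2 to compound 3 (0.28 log units; within the scatter). On that basis compound 3 is estimated at 45 mL/min/kg in this assay, with a range from 18 mL/min/kg to 95 mL/min/kg.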

Compound 3, clearance: 37.2 mL/min/kg
Compound 3: middle estimate off by 1.2-fold (0.08 log units), on the high side; the range from low to high includes it.
By their numbers in this assay, from the lowest: compound 3; then compounds 1 and 2 (each within the scatter of the next).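

In this assay, sulfamoyl in place of hydrogen on an aromatic carbon, meta to a large group, gives a 2.3-fold lower number from compound 2 to compound 3 (0.36 log units; beyond the scatter). For the compounds shown here, this is the first single change with a readable effect, and it shows that this position on the aromatic ring can carry a substituent of four heavy atoms with a modest shift toward a lower number. No measurement shown here accounts for the step.

From the compounds shown here alone, it remains open whether the step is particular to sulfamoyl or would also appear with another group at this place, such as a carboxylic acid, a nitrile, an amine or a methyl group. The compounds also leave open whether sulfamoyl would give a similar step on the aromatic ring of compound 1.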